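The source may hold more compounds than are shown below. What is called first, only, known or untested is meant among the compounds shown, and "the series" means these compounds.

Three compounds have so far been measured in an assay on CHO cells for agonist activity at G protein-coupled receptor GPR35 (Rattus norvegicus), read by a beta-galactosidase reporter and beta-arrestin recruitment, with a stated time of 90 min; a lower number here means that less compound is needed, a higher number that more compound is needed for the effect:

compound 1 `COC(=O)CC(=O)Nc1cccc2c(=O)cc(C(=O)O)oc12` gives 6650 nM
compound 2 `O=C(Nc1cc(Cl)cc2c(=O)cc(C(=O)O)oc12)c1ccc([N+](=O)[O-])cc1` gives 3140 nM
compound 3 `CCCOc1ccc(C(=O)Nc2cccc3c(=O)cc(C(=O)O)oc23)cc1` gives 3610 nM

Compound 1 has the highest number of the three in this assay, meaning that more of it is needed for the effect than of either other compound. Its gap to compound 3 lies within the scatter, so those two cannot be told apart; its gap to compound 2 lies beyond the scatter, so compound 2 clearly needs less.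

The compound to be considered next is compound 4 `O=C(O)c1cc(=O)c2cccc(NC(=O)C3CCCCC3)c2o1`, which differs from compound 1 in one place: cyclohexyl in place of (methoxycarbonyl)methyl on a carbonyl carbon. Within the data shown here, all three measured compounds share the same core and differ only in the group on the carbonyl carbon; no pair among them differs in just one place, so no step of the same kind is available to measure against. The change is expected to produce a step from compound 1 to compound 4 of a 1.7-fold lower number from compound 1 to compound 4 (0.22 log units; within the scatter), with no firm direction beyond the scatter. Compound 4 is therefore estimated at 4000 nM, in the range 1500 nM to 15000 nM.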

Compound 4, half-maximal effective concentration: 1200 nM
The estimate for compound 4 lay 3.3-fold (0.52 log units) above the measured number; the whole stated range lies above it.
By their numbers in this assay, from the lowest: compound 4; then compounds 2, 3 and 1 (each within the scatter of the next, the first and the last beyond it).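

In this assay, among these compounds, cyclohexyl in place of (methoxycarbonyl)methyl on a carbonyl carbon gives a 5.5-fold lower number from compound 1 to compound 4 (0.74 log units; beyond the scatter) and so provides the first reading of a single change at this position. The group on this carbonyl carbon can therefore shift the number beyond the usual scatter, and a ring of carbon only, with no hydrogen-bond acceptors, is accepted here in place of an open group with two. This single step cannot separate the effect of adding the ring from that of removing the acceptors, and no measurement at hand explains the result.

As far as these compounds go, it remains open whether a smaller ring such as cyclopentyl or an unbranched hexyl chain would give a similar number. From the compounds shown here alone, it is also open whether an amine on the cyclohexyl ring would change the number.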